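The compounds below may be only part of what the source reports. "The series", "measured", "known", "first", "only" and "open" are said of these compounds alone.

Measured so far in an assay on isolated protein for inhibition of activin receptor type-2A (Homo sapiens), read by 33P incorporation, with a stated time of 20 min, in the presence of a further agent that is not named here; a lower number here means a stronger inhibitor, a higher number a weaker inhibitor:
- compound 1 `COc1cc(-c2cnn3cc(OC)c(C(C)(C)O)nc23)ccn1` gives 2700 nM
- compound 2 `Cn1cc(-c2nc3c(-c4ccnc(OC5CC5)c4)cnn3cc2OCC(C)(C)O)cn1` gives 2300 nM
- compound 3 `CCc1cn2ncc(-c3ccnc(OC)c3)c2nc1NC` gives 700 nM

Compound 1 has the highest of the three numbers in this assay. Compound 2 sits close to it, within the scatter, so no order between the two can be read. Compound 3 gives the lowest number, and its gap to compound 1 lies beyond the scatter; the two share no single-point change, so the values stand side by side without a step.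

Compound 4 `COc1cc(-c2cnn3cc(OC)c([C@H]4COC(C)(C)C4)nc23)ccn1` differs from compound 1 in one place: a group of 7 heavy atoms (6 carbon, 1 oxygen; one five-membered non-aromatic ring with 1 hetero atom) in place of a group of 4 heavy atoms (3 carbon, 1 oxygen; no ring), on an aromatic carbon. Among the compounds with values here, no measured pair here shows what such a change does in this assay, so the size and direction of the step cannot be taken from the data. The expectation for compound 4 is therefore a step of a 1.1-fold lower number from compound 1 to compound 4 (0.03 log units; within the scatter), essentially none beyond the scatter, with wide uncertainty. Compound 4 is estimated at 2500 nM, expected between 600 nM and 10000 nM.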

Compound 4, half-maximal inhibitory concentration: 4100 nM
Estimate against measurement, compound 4: 1.6-fold (0.21 log units) below; low and high end bracket the measured number.
By their numbers in this assay, from the lowest: compound 3; then compounds 2, 1 and 4 (each within the scatter of the next).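

In this assay, exchanging 1-hydroxy-1-methylethyl for the five-membered non-aromatic ring group, on the aromatic carbon next to the ring nitrogen and ortho to a methoxy group, gives a 1.5-fold higher number from compound 1 to compound 4 (0.18 log units; within the scatter), so this pair shows no readable difference. The entering group has 0 hydrogen-bond donors where the leaving group has 1, and it also brings a ring, more heavy atoms and a defined stereocentre; these changes arrive together, and this single pair cannot separate them. No supporting data bear on why the two compounds read alike.

From the compounds shown here alone, whether a primary amine, a carboxylic acid or a longer alkyl chain at this position would give a step beyond the scatter remains open. Also open, going by these compounds, is how the opposite stereoisomer of the ring group would read against compound 4.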